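This account rests on a few compounds, and the source may have more. Where it says the series, first, only, none or still open, it means among the compounds named here.

Measured so far in a functional assay on HEK293 cells for agonist activity at D(4) dopamine receptor (Homo sapiens), read by FLIPR; a lower number here means that less compound is needed, a higher number that more compound is needed for the effect:
compound 1 `Cc1cccc(Cl)c1NC(=O)CN1CCC(c2ccccn2)CC1`: 60 nM
compound 2 `Cc1cccc(C(=O)NCN2CCC(c3ccccn3)CC2)c1`: 9 nM
compound 3 `O=C(CN1CCC(c2cccc[n+]2[O-])CC1)NC1CCCCC1`: 294 nM

Compound 3 stands highest of the three numbers; its gaps to compound 1 and to compound 2 both lie beyond the scatter. Compound 4 `O=C(CN1CCC(c2cccc[n+]2[O-])CC1)Nc1cccc(Cl)c1` is not yet measured. Its difference from compound 3 is 3-chlorophenyl in place of cyclohexyl on an amide-type nitrogen, an aromatic ring taking the place of a non-aromatic one on the amide-type nitrogen. Going by the values given here, no two measured compounds differ in a single place, so no measured step bears on this change directly. Compounds 1 and 2, which carry aromatic rings on their amide nitrogens, give lower numbers than compound 3, though they differ from it elsewhere as well. The expected step is a 2.9-fold lower number from compound 3 to compound 4 (0.47 log units; beyond the scatter), a decrease beyond the scatter. Compound 4 is estimated at 100 nM, within 30 nM to 400 nM.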

Compound 4, half-maximal effective concentration: 62 nM
Estimate against measurement, compound 4: 1.6-fold (0.21 log units) above, within the range that was stated.
By their numbers in this assay, from the lowest: compound 2; then compounds 1 and 4 (each within the scatter of the next); then compound 3.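

In this assay, going by these compounds alone, the change from cyclohexyl to 3-chlorophenyl on the amide-type nitrogen gives a 4.7-fold lower number from compound 3 to compound 4 (0.68 log units; beyond the scatter) and is the first step that isolates this position. With the rest of the structure held constant, the aromatic ring with its chlorine gives a modest decrease beyond the scatter. Nothing available accounts for the step.

The compounds shown leave open whether the ring change or the chlorine drives the step. Unsubstituted phenyl would separate the two, and fluorine or methoxy in place of chlorine would test the substituent.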